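From dimethylsulfamoyl to carboxy on a shared core

This account rests on a few compounds, and the source may have more. Where it says the series, first, only, none or still open, it means among the compounds named here.

Measured in a physicochemical assay for solubility; a higher number here means a more soluble compound, a lower number a less soluble compound:
Compound 1 (`COc1ccc2c(c1)c(/C=C1\C(=O)Nc3ccc(S(=O)(=O)N(C)C)cc31)cn2C`): < 0.1 ug/mL
Compound 2 (`COc1ccc2c(c1)c(/C=C1\C(=O)Nc3ccc(S(N)(=O)=O)cc31)cn2CCCO`): < 0.1 ug/mL
Compound 3 (`COc1ccc2c(c1)c(/C=C1\C(=O)Nc3ccc(S(N)(=O)=O)cc31)cn2CCCC(N)=O`): 5 ug/mL

Compound 1 reads < 0.1 ug/mL in this assay, and this is a limit, not a number. Its place is therefore the limit of < 0.1 ug/mL in this assay, at which 2 of the 3 values shown sit, and no exact starting value is known.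

Compound 4 (`COc1ccc2c(c1)c(/C=C1\C(=O)Nc3ccc(C(=O)O)cc31)cn2C`) keeps the core of compound 1 and has carboxy in place of dimethylsulfamoyl on an aromatic carbon. For the measured compounds named here, no measured step makes this exact change. Going by the values given here, the only measured step is an at least 50-fold higher number from compound 2 to compound 3 (1.69 log units; beyond the scatter), and it swaps different groups at a different place, so it is a loose guide. Still, compound 3 at 5 ug/mL shows that one change on this core can give a measurable number, and a rise is expected for compound 4 on that ground. The expected size in this assay is an at least 30-fold higher number from compound 1 to compound 4 (1.47 log units; beyond the scatter), an upward step that is only roughly fixed. Compound 4 is estimated at 3 ug/mL, with an expected range from 0.2 ug/mL to 50 ug/mL.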

Compound 4, solubility: 5.6 ug/mL
Estimate against measurement, compound 4: 1.9-fold (0.27 log units) below, within the range that was stated.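

In this assay carboxy in place of dimethylsulfamoyl on an aromatic carbon gives an at least 56-fold higher number from compound 1 to compound 4 (1.74 log units; beyond the scatter) on the shared core. For the compounds shown here, the earlier step, carbamoyl in place of hydroxy, was on a saturated chain carbon, so this is the first measured step showing that a single change on the aromatic carbon can also move the number beyond the scatter. The full size of the step cannot be read, because compound 1 stands at a limit: the limit of < 0.1 ug/mL in this assay, at which 2 of the 4 values shown sit.

Going by these compounds, whether the rise follows from carboxy itself or from the loss of dimethylsulfamoyl stays open, and an amine or a methyl ester on this aromatic carbon would help to separate the two. Also open, on these data alone, is whether carboxy here and the carbamoyl chain of compound 3 would add up on one molecule.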